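Aryl exchange from compound 2 to compound 3

The source may report more compounds than this note shows. Statements on the series, on what has been measured and on what is new or still open speak of the compounds shown alone.

In a functional assay on LoVo cells (Homo sapiens) for inhibition, read by MTT assay, with a stated time of 24 h (a higher number here means a weaker inhibitor, a lower number a stronger inhibitor), compound 1 `CC1(C)[C@H]2CC[C@]1(C)N(Cc1cn(-c3ccc(F)cc3)nn1)C(=O)C2` gives 40 nM and compound 2 `Cc1ccc(-n2cc(CN3C(=O)C[C@@H]4CC[C@@]3(C)C4(C)C)nn2)cc1` gives 50 nM so compound 2 cannot be separated from compound 1 on these numbers. The change to compound 3 `CC1(C)[C@H]2CC[C@]1(C)N(Cc1cn(-c3cccc(Br)c3)nn1)C(=O)C2` is 3-bromophenyl in place of 4-methylphenyl on an aromatic nitrogen in words 3-bromophenyl in place of 4-methylphenyl on an aromatic nitrogen, with the shared core kept. Among the compounds with values here, one measured step bears on it: a 1.3-fold higher number from compound 1 to compound 2 (0.10 log units; within the scatter) for methyl in place of fluoro on an aromatic carbon, which lies within the scatter. Within the data shown here, no measured compound carries a 3-bromophenyl group, so this single small step is weak guidance. The estimate is a 1.1-fold lower number from compound 2 to compound 3 (0.05 log units; within the scatter) in this assay and no shift beyond the scatter is expected. Compound 3 is expected at 45 nM with an estimated range of 20 nM to 100 nM in this series.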

Compound 3, half-maximal inhibitory concentration: 30 nM
Compound 3: the middle estimate sits 1.5-fold (0.18 log units) above what was measured; the measured number falls inside the stated range.
By their numbers in this assay, from the lowest: compounds 3, 1 and 2 (each within the scatter of the next).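

In this assay, 3-bromophenyl in place of 4-methylphenyl on the aromatic nitrogen gives a 1.7-fold lower number from compound 2 to compound 3 (0.22 log units; within the scatter), and 3-bromophenyl in place of 4-fluorophenyl gives a 1.3-fold lower number from compound 1 to compound 3 (0.12 log units; within the scatter). The earlier step changed only the group on an aromatic carbon of the 4-substituted phenyl, whereas these steps also change where the substituent stands on the phenyl ring, and the three compounds still cannot be separated in this assay. No evidence is available that bears on this result.

Compound 3 differs from compound 1 and compound 2 in both the substituent and its ring position, so the two changes remain unseparated; 4-bromophenyl would bear on that. Also open, as far as these compounds go, is whether an amine or a carboxylic acid on the phenyl ring would give a step beyond the scatter.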